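Amide to Urea on a Shared Pyrazole-Free Core Description

The source may hold more compounds than are shown below. What is called first, only, known or untested is meant among the compounds shown, and "the series" means these compounds.

Of the compounds shown here, two have been measured in a functional assay on A498 cells (Homo sapiens) for inhibition, read by sulforhodamine B assay, with a stated time of 48 h; on this read-out lower numbers stand for stronger inhibition of growth and higher numbers for weaker inhibition of growth. Compound 1, with structure `O=C(Nc1cccc(-n2cc(-c3ccncc3)c(-c3ccc(Cl)c(O)c3)n2)c1)Nc1ccc(Cl)c(Cl)c1`, gives 940 nM. Compound 2, with structure `COc1cc(-c2nn(-c3cccc(NC(=O)c4cccc(C(F)(F)F)c4)c3)cc2-c2ccncc2)ccc1Cl`, gives 687 nM. Compound 2 stands with the lowest of the two numbers, but its gap to compound 1 lies within the scatter of repeated measurements, so the two compounds cannot be separated on this read-out.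

Compound 3, with structure `COc1cc(-c2nn(-c3cccc(NC(=O)Nc4ccc(Cl)c(C(F)(F)F)c4)c3)cc2-c2ccncc2)ccc1Cl`, has not been measured. It differs from compound 2 in one place: (4-chloro-3-(trifluoromethyl)phenyl)amino in place of 3-(trifluoromethyl)phenyl on a carbonyl carbon. The amide of compound 2 thus becomes a urea, carrying an added hydrogen-bond donor, and the aromatic ring gains a chlorine.

Among the measured compounds shown here, no directly comparable pair has been measured, so the size of this step is open. Compound 1 also carries a urea on the same side of its core and gives 940 nM, a number within the scatter of compound 2. The step from compound 2 to compound 3 in this assay is therefore expected to be small, a 1.1-fold lower number from compound 2 to compound 3 (0.02 log units; within the scatter), with no clear direction beyond the scatter. Compound 3 is estimated at 650 nM, within a range from 250 nM to 1700 nM.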

Compound 3, concentration for 50% growth inhibition: 837 nM
Beside the measured number, compound 3's estimate is 1.3-fold (0.11 log units) below it; the measured number falls inside the stated range.
By their numbers in this assay, from the lowest: compounds 2, 3 and 1 (each within the scatter of the next).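

Among the compounds shown here, the first direct comparison at this carbonyl carbon shows that replacing 3-(trifluoromethyl)phenyl with (4-chloro-3-(trifluoromethyl)phenyl)amino gives a 1.2-fold higher number from compound 2 to compound 3 (0.09 log units; within the scatter) in this assay and turns the amide into a urea without a change that this read-out can separate from scatter. The entering group is larger and brings one hydrogen-bond donor, yet the two compounds cannot be told apart here, so this position accepts this particular change with no measurable gain or loss in growth inhibition. No measurement offered here explains why the number stays within the scatter.

The step makes two changes at once, so the compounds shown cannot say whether the added amino link and the added chlorine each do nothing or instead offset each other, and (3-(trifluoromethyl)phenyl)amino on the same carbonyl carbon would separate the two. Going by these compounds, it also remains open whether this position stays as undemanding with a very different group on the carbonyl carbon, such as a piperazine ring or a carboxylic acid in place of the aromatic ring.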